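Methylsulfonyl for methoxycarbonyl on two cores: cytotoxicity notes

The compounds below may be only part of what the source reports. "The series", "measured", "known", "first", "only" and "open" are said of these compounds alone.

Compound 1 `COC(=O)c1ccc(NC(=O)CSc2nc3ccccc3n2S(=O)(=O)c2cc(C)cc(C)c2)cc1` and compound 2 `Cc1cc(C)cc(S(=O)(=O)n2c(SCC(=O)Nc3ccc(S(C)(=O)=O)cc3)nc3ccccc32)c1` share one core; compound 3 `COC(=O)c1ccc(NC(=O)COc2nc3ccccc3n2S(=O)(=O)c2cc(C)cc(C)c2)c(Cl)c1` and the unmeasured compound 4 `Cc1cc(C)cc(S(=O)(=O)n2c(OCC(=O)Nc3ccc(S(C)(=O)=O)cc3Cl)nc3ccccc32)c1` share another. The difference between the two cores is not broken down here.

In an ADME assay on MT4 cells (Homo sapiens) for cytotoxicity, read by MTT assay, with a stated time of 5 days (a lower number here means that less compound is tolerated, a higher number that more compound is tolerated), compound 1 gives 10000 nM, and compound 2 gives 10600 nM. The change between them is methylsulfonyl in place of methoxycarbonyl on an aromatic carbon, and the step it made is a 1.1-fold higher number from compound 1 to compound 2 (0.03 log units; within the scatter).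

Compound 3 gives 119000 nM in this assay, the highest number of the three measured compounds, with gaps to compound 1 and compound 2 that are beyond the scatter.

Compound 4 carries the same kind of change on its own core: methylsulfonyl in place of methoxycarbonyl on an aromatic carbon. The place differs in that here the site is meta to a chloro group, which is absent in the earlier pair.

Because a 1.1-fold higher number from compound 1 to compound 2 (0.03 log units; within the scatter) lies within the scatter, compound 4 is expected to stay near compound 3. On that ground the expected step is a 1.1-fold higher number from compound 3 to compound 4 (0.02 log units; within the scatter). Compound 4 is thus estimated at 125000 nM, between 60000 nM and 260000 nM.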

Compound 4, half-maximal cytotoxic concentration: > 228000 nM
Compound 4 was reported as a limit (the forecaster's own chance of this, stated with the estimate: 20%); at least 1.8-fold (0.26 log units) between middle value and limit.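

In this assay, replacing methoxycarbonyl with methylsulfonyl on the core of compound 3 gives an at least 1.9-fold higher number from compound 3 to compound 4 (0.28 log units; that floor lies within the scatter), and this figure is a floor rather than a measured size. Compound 4 stands only as a limit: the limit of > 228000 nM in this assay, at which 1 of the 4 values shown sits. On the two cores shown, the change brings no lower number, but this does not establish that the size of the step carries from one core to the other: the same change on two cores in this assay, a 1.1-fold higher number (0.03 log units; within the scatter) from compound 1 to compound 2 and an at least 1.9-fold higher number (0.28 log units; that floor lies within the scatter) from compound 3 to compound 4; the limit leaves it open whether they differ.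

The compounds shown leave open how far the true number of compound 4 lies beyond the limit, and whether the two steps are in fact alike. They also leave open how a carboxylic acid or an amine at the same place on the ring would read in this assay, and what the chloro group contributes on its own, as no pair shown changes that group alone.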